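This account rests on a few compounds, and the source may have more. Where it says the series, first, only, none or still open, it means among the compounds named here.

Compound 1 `O=C(Nc1ccc(Cl)cc1)Nc1ccc(C(=O)NO)cc1` and compound 2 `O=C(CCc1ccc(NC(=O)Nc2ccccc2)cc1)NO` have both been tested in a functional assay on MCF7 cells (Homo sapiens) for cytotoxicity, read by MTT assay, with a stated time of 72 h; a higher number here means a weaker inhibitor, a lower number a stronger inhibitor. Compound 1 gives > 50000 nM, which is a limit of the assay and not a number. Compound 2 gives > 50000 nM, which is also only a limit. Compound 2 therefore has no exact value to start from, and the measurements so far amount to the limit of > 50000 nM in this assay, at which 2 of the 2 values shown sit.

Compound 3 `O=C(CCc1ccc(NC(=O)Nc2ccc(Cl)cc2)cc1)NO` differs from compound 2 in one place: chloro in place of hydrogen on an aromatic carbon. Chloro takes the place of hydrogen on an aromatic carbon, para to a large group, so phenyl becomes 4-chlorophenyl. Among the measured compounds shown here, no measured pair shows this change on its own. Compound 1 already carries a 4-chlorophenyl group, and its result is the limit > 50000 nM. That gives little reason to expect a large gain in this assay, so any expected shift towards a stronger inhibitor is slight, and compound 3 may also return only a limit. The estimated step of an at least 1.1-fold lower number from compound 2 to compound 3 (0.04 log units; that floor lies within the scatter) is expected to stay within the usual scatter. For compound 3 the estimate is 45000 nM, with an expected range from 15000 nM to 80000 nM.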

Compound 3, half-maximal inhibitory concentration: > 50000 nM
Compound 3 ended at the assay's limit; the forecaster's own chance of this, stated with the estimate: 60%; at least 1.1-fold (0.04 log units) between middle value and limit.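

The steps from compound 2 to compound 3 and from compound 1 to compound 3 cannot be read, because all three compounds return a limit and not a number: the limit of > 50000 nM in this assay, at which 3 of the 3 values shown sit.

The compounds shown leave open whether chloro in place of hydrogen, or 2-(hydroxycarbamoyl)ethyl in place of hydroxycarbamoyl, changes the result in this assay at all.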